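Swapping bromo for methoxy on the aryl ring of compound 2

The source may report more compounds than this note shows. Statements on the series, on what has been measured and on what is new or still open speak of the compounds shown alone.

Measured compounds:
- compound 1, `CSc1ncc(-c2ccc(S(C)(=O)=O)cc2)n1-c1ccc(F)cc1`: 18.7%
- compound 2, `CSc1ncc(-c2ccc(S(C)(=O)=O)cc2)n1-c1ccc(Br)cc1`: 88%

In a functional assay on the whole organism (strain Sprague-Dawley) with Rattus norvegicus as the target, read by paw edema, with a stated time of 5 h, at a dose of 50 mg/kg by the oral route (on this read-out lower numbers stand for less inhibition and higher numbers for more inhibition at the one dose given (going by the name of the read-out)), compound 2 stands highest of the two numbers measured. Among the measured compounds shown here, the only neighbour is compound 1, and the step of a number 69.3 percentage points higher from compound 1 to compound 2 (beyond the scatter) shows a large rise, beyond the scatter, when bromo replaces fluoro on an aromatic carbon. Compound 3, `COc1ccc(-n2c(-c3ccc(S(C)(=O)=O)cc3)cnc2SC)cc1`, has not yet been measured. It differs from compound 2 by methoxy in place of bromo on an aromatic carbon; the group sits on an aromatic carbon of a six-membered aromatic ring of carbon only, para to a large group.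

For the measured compounds named here, no measured step involves methoxy, so the one step from compound 1 to compound 2 bears on the new change only loosely: it shows that this position is sensitive and that a small change there can move this assay by a large amount. Because compound 2 reads 88% and compound 1 reads 18.7%, the estimate for compound 3 is placed between them, nearer the middle, with a wide range: 55%, from 20% to 90%, a step of a number 33 percentage points lower from compound 2 to compound 3 (beyond the scatter) expected.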

Compound 3, a percentage reported as inhibition, in the whole organism at one dose (the size of the read-out at that dose, not a potency): 34.3%
Estimate against measurement, compound 3: 20.7 percentage points above; low and high end bracket the measured number.
By their numbers in this assay, from the lowest: compound 1; then compound 3; then compound 2.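

In this assay the change of bromo to methoxy on this aromatic carbon gives a number 53.7 percentage points lower from compound 2 to compound 3 (beyond the scatter) and so removes most of the high reading of compound 2, which shows that the large effect at this place is not confined to the swap between the two halogens. Methoxy in place of fluoro gives a number 15.6 percentage points higher from compound 1 to compound 3 (beyond the scatter) and this is a modest step, so the three groups now stand in a clear order, with fluoro lowest, methoxy in the middle and bromo highest, and the count of heavy atoms does not follow that order, since methoxy has the most atoms yet does not read highest. No measurement available here explains why the groups fall in this order.

The compounds shown leave open how chloro, an amine or a carboxylic acid would read on this same aromatic carbon, and whether any of these would come close to bromo in compound 2. They also leave open whether the same order of groups would hold if the rest of the shared core were changed.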